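A second oxetan-3-yl on the amine nitrogen

The source may report more compounds than this note shows. Statements on the series, on what has been measured and on what is new or still open speak of the compounds shown alone.

Compound 1 `NC(=O)NCCCCN(C[C@H]1Cc2ncccc2CN1)[C@H]1CCCc2cccnc21`: 7 nm/s
Compound 2 `c1cnc2c(c1)CN[C@@H](CN(CCCCNC1COC1)[C@H]1CCCc3cccnc31)C2`: 7 nm/s

Among the compounds with values here, in an ADME assay for permeability, using PAMPA, with a stated time of 4 h, at pH 5.5 (on this read-out lower numbers stand for lower permeability and higher numbers for higher permeability), compound 2 stands level with compound 1, its only measured neighbour. Compound 3 `c1cnc2c(c1)CN[C@@H](CN(CCCCN(C1COC1)C1COC1)[C@H]1CCCc3cccnc31)C2` keeps the structure of compound 2 but has oxetan-3-yl in place of hydrogen on an amine nitrogen. Within the data shown here, one measured step bears on this: no change at the digits printed from compound 1 to compound 2 (within the scatter), where oxetan-3-yl took the place of carbamoyl on an amine nitrogen. A single step is thin evidence, but it gives no ground for expecting a large move, so the expected change is slight and no step beyond the scatter is foreseen: a 1.4-fold higher number from compound 2 to compound 3 (0.15 log units; within the scatter). For compound 3 the estimated value is 10 nm/s, with an expected range of 5 nm/s to 30 nm/s.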

Compound 3, apparent permeability: 62 nm/s
The estimate for compound 3 lay 6.2-fold (0.79 log units) below the measured number, and the stated range ends below it.
By their numbers in this assay, from the lowest: compounds 1 and 2 (each within the scatter of the next); then compound 3.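

In this assay this amine nitrogen proves sensitive to what it carries: oxetan-3-yl in place of the remaining hydrogen brings an 8.9-fold higher number from compound 2 to compound 3 (0.95 log units; beyond the scatter) and thus a real move, which the earlier exchange of carbamoyl for a single oxetan-3-yl did not produce. The comparison with the carbamoyl compound gives the same size, an 8.9-fold higher number from compound 1 to compound 3 (0.95 log units; beyond the scatter) and no smaller. Nothing available explains this rise. From the compounds shown here alone, whether the rise depends on oxetan-3-yl itself or would also follow from a methyl or a cyclobutyl on that nitrogen stays open.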